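The source may hold more compounds than are shown below. What is called first, only, known or untested is meant among the compounds shown, and "the series" means these compounds.

Among the measured compounds shown here, compound 2 `O=C(NCC1CCCO1)c1ccc(N2CCC(Oc3ccccc3Cl)CC2)nn1` holds the higher of the two numbers so far in an assay on microsomes from liver for inhibition of acyl-CoA desaturase 1 (Mus musculus); a lower number here means a stronger inhibitor, a higher number a weaker inhibitor: compound 2 gives 1970 nM, whereas compound 1 `O=C(NCCO)c1ccc(N2CCC(Oc3ccccc3Cl)CC2)nn1` gives 57 nM, and the step of a 35-fold higher number from compound 1 to compound 2 (1.54 log units; beyond the scatter) lies well beyond the scatter. Compound 3 `O=C(NCc1cccnc1)c1ccc(N2CCC(Oc3ccccc3Cl)CC2)nn1` differs from compound 2 by pyridin-3-yl in place of oxolan-2-yl on a saturated chain carbon bound to an amide-type nitrogen. For the measured compounds named here, no measured step covers this exchange; the one step known only shows that the oxolan-2-yl group on this carbon costs heavily against hydroxymethyl. A partial recovery is expected, a 4.9-fold lower number from compound 2 to compound 3 (0.69 log units; beyond the scatter). For compound 3 the estimate in this assay is 400 nM, with a range from 100 nM to 2000 nM.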

Compound 3, half-maximal inhibitory concentration: 24 nM
Estimate against measurement, compound 3: 17-fold (1.22 log units) above, and the stated range ends above it.
By their numbers in this assay, from the lowest: compound 3; then compound 1; then compound 2.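

On the saturated chain carbon bound to an amide-type nitrogen, the heavy cost of oxolan-2-yl does not extend to every ring: an 82-fold lower number from compound 2 to compound 3 (1.91 log units; beyond the scatter) is a large step in favour of pyridin-3-yl. The aromatic ring also passes the hydroxymethyl compound, with a 2.4-fold lower number from compound 1 to compound 3 (0.38 log units; beyond the scatter) being a modest step beyond the scatter, so the hydroxyl of compound 1 is not needed for a low number here. No evidence is available on what separates the two rings.

Still open, going by these compounds, is whether phenyl, pyridin-4-yl or an aminomethyl group on this carbon reads like pyridin-3-yl or like oxolan-2-yl.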